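The source may report more compounds than this note shows. Statements on the series, on what has been measured and on what is new or still open speak of the compounds shown alone.

Of the compounds shown here, two have been measured in a functional assay on BMEC cells (Bos taurus) for antiproliferative activity; on this read-out lower numbers stand for stronger inhibition and higher numbers for weaker inhibition. Compound 1 `COc1cc(/C=C\Cc2cc(OP(=O)(O)O)c3ccoc3c2)cc(OC)c1OC` gives 340 nM, and compound 2 `COc1cc(/C=C\Cc2cc(O)c3occc3c2)cc(OC)c1OC` gives 54 nM. Compound 2 therefore holds the lower of the two numbers, and its gap to compound 1 lies beyond the scatter. The next compound, compound 3 `COc1cc(/C=C/Cc2cc(O)c3occc3c2)cc(OC)c1OC`, has the same atoms and bonds as compound 2 and differs only in configuration as drawn: the two compounds have the same atoms and bonds and differ only in configuration as drawn: 1 of 1 stereo elements differ; a double bond is drawn Z in compound 2 and E in compound 3. A double bond is drawn Z in compound 2 and E in compound 3. Within the data shown here, no measured pair shows what such a change does in this assay, so the expectation here is a judgment and cannot be read from a measured step. A step to a higher number, meaning weaker inhibition, is expected to lie beyond the scatter, although its size is uncertain and a step within the scatter cannot be ruled out. The expected change is a 7.4-fold higher number from compound 2 to compound 3 (0.87 log units; beyond the scatter). For compound 3 the estimated value is 400 nM, with an expected range of 80 nM to 3000 nM.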

Compound 3, half-maximal inhibitory concentration: 8400 nM
Compound 3: the middle estimate sits 21-fold (1.32 log units) below what was measured; the measured number lies above the stated range.
By their numbers in this assay, from the lowest: compound 2; then compound 1; then compound 3.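

Changing only the double bond carries a 160-fold higher number from compound 2 to compound 3 (2.19 log units; beyond the scatter) in this assay. This shows that the configuration of this double bond has a large bearing on the read-out, something compound 1 and compound 2 could not show, as both are drawn Z. The step can be assigned to the configuration alone, because nothing else separates the two structures: the fact that compounds 2 and 3 differ only in the configuration as drawn

The compounds shown leave open whether the same change would have a step of similar size with the phosphate group of compound 1, since only this one Z and E pair is at hand, and they give no reason for the step beyond the configuration itself. They also leave open how an amine or a carboxylic acid in place of the hydroxyl group would read in this assay, and whether a saturated chain in place of the double bond would stand nearer to compound 2 or to compound 3.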